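The source may hold more compounds than are shown below. What is called first, only, known or untested is meant among the compounds shown, and "the series" means these compounds.

Compound 1 `Cc1ccc(-n2cnc3cnc(-c4ccc(F)cc4C)cc32)cc1` and compound 2 `COc1cnc(-n2cnc3cnc(-c4ccc(F)cc4C)cc32)cn1` share one core, and compound 3 `COc1ncc(-n2cnc3cnc(-c4ccc(F)cc4C)cc32)cn1` has not yet been tested. Among the measured compounds shown here, in an ADME assay on S9 fraction from liver (Mus musculus) for metabolic stability, read by LC-MS, using NADPH, with a stated time of 45 min, tested at 3 uM, in the presence of a further agent that is not named here (a higher number here means that the liver removes a larger share of the compound in one pass, a lower number that the liver removes a smaller share), compound 2 gives 0.66, the only number available, while in this assay compound 1 gives "not determined" (no result reported). Compound 3 differs from compound 2 in that (2-methoxypyrimidin-5-yl in place of 5-methoxypyrazin-2-yl on an aromatic nitrogen). For the measured compounds named here, with no measured pair to lean on, the expected step from compound 2 to compound 3 is no change at the digits printed from compound 2 to compound 3 (within the scatter), which lies within the usual scatter. Compound 3 is therefore estimated at 0.66, with a plausible range from 0.5 to 0.8.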

Compound 3, hepatic extraction ratio in the Mus musculus assay: 0.11
Beside the measured number, compound 3's estimate is 0.55 above it; the whole stated range lies above it.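

Exchanging 5-methoxypyrazin-2-yl for 2-methoxypyrimidin-5-yl, the same atoms joined differently, gives in the Mus musculus assay a number 0.55 lower from compound 2 to compound 3 (beyond the scatter), so at this position the arrangement of the ring matters and not only its atom count. In a physicochemical assay for solubility (a higher number here means a more soluble compound, a lower number a less soluble compound), compound 2 gives 16000 nM. In the physicochemical assay compound 3 gives > 200000 nM, which is a limit of the assay and not a number.

This single pair cannot show whether the same swap would act alike on another core. Also open, going by these compounds, is how either read-out would respond to an amine in place of the methoxy group on 2-methoxypyrimidin-5-yl.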